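From methyl to chloro at the assay limit

A few compounds are considered here, and "the series" means these few. Any claim that something is new, unique, unknown or untested is made for them only; others in the source may bear on it.

Compound 1 `Cc1ccc(NCc2cn(-c3ccccc3)nc2-c2ccc(Cl)cc2)cc1`: > 100000 nM
Compound 2 `Cc1ccc(NCc2cn(-c3ccccc3)nc2-c2ccc(C(F)(F)F)cc2)cc1`: > 100000 nM
Compound 3 `Cc1ccc(NCc2cn(-c3ccccc3)nc2-c2ccccc2)cc1`: > 100000 nM

These compounds were tested in an ADME assay on MDBK cells (Bos taurus) for cytotoxicity, read by MTT assay, with a stated time of 72 h (on this read-out higher numbers stand for lower toxicity in this test and lower numbers for higher toxicity in this test), and each entry above is a limit of the assay, not an exact number. Compound 1 therefore has no exact position on the scale, and the shared picture is the limit of > 100000 nM in this assay, at which 3 of the 3 values shown sit.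

Compound 4 `Clc1ccc(NCc2cn(-c3ccccc3)nc2-c2ccc(Cl)cc2)cc1` turns the 4-methylphenyl group of compound 1 into 4-chlorophenyl: chloro in place of methyl on an aromatic carbon. Going by the values given here, no measured step makes this exchange. Three steps change a different group instead: a step that the two limits leave unreadable from compound 1 to compound 2, a step that the two limits leave unreadable from compound 1 to compound 3 and a step that the two limits leave unreadable from compound 2 to compound 3. They give no size to carry over, so they are only a weak guide.

The expectation for compound 4 rests on the limit shared by the three measured compounds, and no direction can be named with confidence. The expected change is a number no higher from compound 1 to compound 4 (the limit leaves the size open), with nothing expected beyond the usual scatter. Compound 4 is estimated at 100000 nM, with an expected range from 45000 nM to 100000 nM.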

Compound 4, half-maximal cytotoxic concentration: > 100000 nM
Compound 4 was reported as a limit (the forecaster's own chance of this, stated with the estimate: 75%); the middle value sits exactly at the limit.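

In this assay compound 4 gives > 100000 nM, which is a limit of the assay. Compound 1 also sits at a limit, so no step from methyl to chloro can be read between compound 1 and compound 4: the limit of > 100000 nM in this assay, at which 4 of the 4 values shown sit.

The compounds shown leave open how far any of them lies beyond that limit.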